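This account rests on a few compounds, and the source may have more. Where it says the series, first, only, none or still open, it means among the compounds named here.

Compound 1 `CC(=O)Nc1ccc(O)c(C(=O)/C=C/c2ccccc2)c1` was examined in an ADME assay on MT4 cells (Homo sapiens) for cytotoxicity, read by MTT assay, with a stated time of 4 days (a lower number here means that less compound is tolerated, a higher number that more compound is tolerated), and there compound 1 gave 49400 nM. Compound 2 `COc1ccc(/C=C/C(=O)c2cc(NC(C)=O)ccc2O)cc1` differs from compound 1 by methoxy in place of hydrogen on an aromatic carbon, and in this assay compound 2 gave 38700 nM; the step of a 1.3-fold lower number from compound 1 to compound 2 (0.11 log units; within the scatter) was therefore small. Compound 3 `Nc1ccc2oc(-c3ccccc3)c(O)c(=O)c2c1` rests on a different core, and the difference between the two cores is not broken down here; in this assay compound 3 gave 217000 nM, the highest number of the three, beyond the scatter from both compound 1 and compound 2.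

Compound 4 `COc1ccccc1-c1oc2ccc(N)cc2c(=O)c1O` is derived from compound 3 by methoxy in place of hydrogen on an aromatic carbon. Going by the values given here, this is the same kind of change as the one from compound 1 to compound 2, but not the same: in compound 2 the methoxy stands para to a large group, while in compound 4 it stands ortho to a large group. Among the compounds with values here, the only measured example of this kind of change, the step of a 1.3-fold lower number from compound 1 to compound 2 (0.11 log units; within the scatter), lies within the scatter, so the step of a 1.2-fold lower number from compound 3 to compound 4 (0.08 log units; within the scatter) for compound 4 is expected to be small as well, because a 1.3-fold lower number from compound 1 to compound 2 (0.11 log units; within the scatter) shows the added methoxy changed little. On that basis compound 4 is expected to give 180000 nM in this assay, with a plausible range from 90000 nM to 360000 nM.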

Compound 4, half-maximal cytotoxic concentration: 222000 nM
The estimate for compound 4 lay 1.2-fold (0.09 log units) below the measured number; the range from low to high includes it.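

In this assay, methoxy in place of hydrogen on an aromatic carbon gave a 1.0-fold higher number from compound 3 to compound 4 (0.01 log units; within the scatter), so on the core of compound 3 this change left the number where it stood, as it did on the core of compound 1. Set side by side, the two steps give no sign that the outcome of this change depends on the core, and in this narrow sense it carried over from one core to the other: the same change on two cores in this assay, a 1.3-fold lower number (0.11 log units; within the scatter) from compound 1 to compound 2 and a 1.0-fold higher number (0.01 log units; within the scatter) from compound 3 to compound 4, 1.3-fold (0.12 log units) apart, within the scatter of two such steps

This does not show that the change would behave the same way on any further core, since the comparison rests on a single pair for each of two cores and on this one read-out alone. Nor is it a test of one fixed place, as the methoxy in compound 4 stands ortho to a large group, whereas in compound 2 it stands elsewhere on its ring.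

The compounds shown leave open whether a group other than methoxy, such as hydroxy, a longer ethoxy chain, an amine or a carboxylic acid, would also leave the number unmoved on both cores. They also leave open whether methoxy in another place on the ring of compound 3 would do the same.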